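A few compounds are considered here, and "the series" means these few. Any claim that something is new, unique, unknown or untested is made for them only; others in the source may bear on it.

The measured compounds:
Compound 1, `O=C(O)CCCCCOc1cc(-c2ccccc2Cl)cc(-c2ccccc2)n1`. In a functional assay on cells for inhibition of leukotriene B4 receptor 1 (Homo sapiens) (on this read-out lower numbers stand for stronger inhibition and higher numbers for weaker inhibition), compound 1 reaches only a limit of the assay, > 10000 nM.
Compound 2, `O=C(O)CCCCCOc1cc(-c2ccccc2)cc(-c2ccc(F)cc2)n1`. In this assay compound 2 also reaches only a limit, > 10000 nM.
Compound 3, `O=C(O)CCCCCOc1cc(-c2ccccc2)cc(-c2ccccc2)n1`. In this assay compound 3 gives 2000 nM.

Compound 3 is therefore the only one of the three with an actual number; the other two values are limits, as the limit of > 10000 nM in this assay, at which 2 of the 3 values shown sit, records. Both measured steps lead to compound 3: an at least 5.0-fold lower number from compound 1 to compound 3 (0.69 log units; beyond the scatter) and an at least 5.0-fold lower number from compound 2 to compound 3 (0.69 log units; beyond the scatter). Each of them concerns a substituent on one of the aromatic rings, not the chain that carries the carboxy group.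

Compound 4, `CC(C)(CCCCCCOc1cc(-c2ccccc2)cc(-c2ccccc2)n1)C(=O)O`, differs from compound 3 only on that chain: 2-carboxy-2-methylpropyl in place of carboxy on a saturated chain carbon, five bonds along the chain from an oxygen on an aromatic ring. Going by the values given here, no measured step touches this part of the molecule, so the measured compounds give no indication of which way such a change moves the read-out. The step of a 1.3-fold lower number from compound 3 to compound 4 (0.12 log units; within the scatter) is expected to stay within the scatter, with a wide range around it. Compound 4 is estimated at 1500 nM in this assay, between 300 nM and 8000 nM.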

Compound 4, half-maximal inhibitory concentration: 100 nM
Estimate against measurement, compound 4: 15-fold (1.18 log units) above, outside the stated range (below it).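

Changing the end of the chain moves the read-out strongly: with 2-carboxy-2-methylpropyl in place of carboxy, there is a 20-fold lower number from compound 3 to compound 4 (1.30 log units; beyond the scatter), while the aromatic rings stay untouched. The earlier steps shown here concerned only substituents on those rings, where the compounds carrying chloro or fluoro gave weaker inhibition than compound 3. This position on the chain is therefore a place where inhibition can be strengthened, and a carboxy group is still present in compound 4.

This one change lengthens the chain and adds methyl branching together, so the compounds shown cannot separate the two effects; a straight chain of the same length without methyl groups, or an amide in place of the carboxylic acid, remains an open case. Nothing given here explains why the read-out moves this far.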